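This account rests on a few compounds, and the source may have more. Where it says the series, first, only, none or still open, it means among the compounds named here.

In a functional assay on HCT-15 cells (Homo sapiens) for cytotoxicity, read by sulforhodamine B assay, with a stated time of 48 h, tested at 1 uM (a higher number here means a weaker effect of the compound at the concentration tested, a lower number a stronger effect), the measured compounds gave:
compound 1 `COc1cc(-c2cc(/C=C/C(=O)c3ccc(Cl)c(Cl)c3)[nH]n2)cc(OC)c1OC`: 86%
compound 2 `COc1ccc(-c2cc(/C=C/C(=O)c3ccc(N)cc3)[nH]n2)cc1`: 50%
compound 3 `COc1cc(C(=O)/C=C/c2cc(-c3cc(OC)c(OC)c(OC)c3)n[nH]2)cc(OC)c1OC`: 76%

Among these three numbers compound 1 stands highest in this assay with 86%. Compound 3 comes nearest to it at 76%, a gap within the scatter, so the two cannot be ordered. Compound 2 lies furthest away at 50%, a gap beyond the scatter. Compound 4 `COc1cc(-c2cc(/C=C/C(=O)c3ccc(F)c(F)c3)[nH]n2)cc(OC)c1OC` has not yet been measured. It differs from compound 1 in one place: 3,4-difluorophenyl in place of 3,4-dichlorophenyl on a carbonyl carbon. Among the compounds with values here, no measured pair shows this exchange, so its effect can only be expected. The expected step in this assay is a number 2 percentage points higher from compound 1 to compound 4 (within the scatter), none beyond the scatter. Compound 4 is therefore estimated at 88% in this assay, within 72% to 100%.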

Compound 4, a percentage reported as activity, at one concentration (the size of the read-out at that concentration, not a potency): 88%
Estimate against measurement, compound 4: no gap at the digits printed; measured number inside the range.
By their numbers in this assay, from the lowest: compound 2; then compounds 3, 1 and 4 (each within the scatter of the next, the first and the last beyond it).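

In this assay, placing 3,4-difluorophenyl in place of 3,4-dichlorophenyl on a carbonyl carbon gives a number 2 percentage points higher from compound 1 to compound 4 (within the scatter). This first measured exchange at this place therefore does not separate the two dihalogenated rings, and the read-out does not register the change from chlorine to fluorine here. Nothing available explains this result.

Still open, on these data alone, is what an unsubstituted phenyl, a 3,4-dibromophenyl or a pyridine ring would give on this carbonyl carbon with the core of compound 1. Also open, as far as these compounds go, is whether the exchange would read the same on another core.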